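A Second Chloro on the Core of Compound 1

A few compounds are considered here, and "the series" means these few. Any claim that something is new, unique, unknown or untested is made for them only; others in the source may bear on it.

Of the compounds shown here, three have been measured in a functional assay on NCI/ADR-RES cells (Homo sapiens) for cytotoxicity, read by sulforhodamine B assay, with a stated time of 48 h; a higher number here means a weaker inhibitor of growth, a lower number a stronger inhibitor of growth. Compound 1 `ClCc1ccc(Cn2cnc3c(Cl)ncnc32)cc1` gives 1510 nM, the lowest number of the three. Compound 2 `ClCc1cccc(Cn2cnc3c(Cl)nc(Cl)nc32)c1` gives 2390 nM in this assay, a number that lies within the usual scatter of the value of compound 1, so the two cannot be told apart. Compound 3 `Nc1nc(Cl)c2ncn(Cc3ccccc3CCl)c2n1` gives 4470 nM, a number clearly higher than that of compound 1, meaning weaker growth inhibition.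

Compound 4 `ClCc1ccc(Cn2cnc3c(Cl)nc(Cl)nc32)cc1` has not yet been measured. It differs from compound 1 by chloro in place of hydrogen on an aromatic carbon. Going by the values given here, compound 2 also carries a chloro at this position of its core, yet its value is indistinguishable from that of compound 1, although it also differs from compound 1 elsewhere, so no clean single step guides the expectation.

Accordingly, the step from compound 1 to compound 4 is expected to be small, a 1.2-fold higher number from compound 1 to compound 4 (0.08 log units; within the scatter), with no clear direction beyond the scatter. Compound 4 is thus estimated at 1800 nM, within a range from 800 nM to 4000 nM.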

Compound 4, concentration for 50% growth inhibition: 16600 nM
Beside the measured number, compound 4's estimate is 9.2-fold (0.96 log units) below it, outside the stated range (above it).
By their numbers in this assay, from the lowest: compounds 1, 2 and 3 (each within the scatter of the next, the first and the last beyond it); then compound 4.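

On the core of compound 1, a single chloro in place of hydrogen on an aromatic carbon, between two ring nitrogen atoms, is far from a small change: in this assay it gives an 11-fold higher number from compound 1 to compound 4 (1.04 log units; beyond the scatter), which means much weaker growth inhibition. Compounds 1, 2 and 3 could not show this, as no two of them differ in only one place, whereas here one added heavy atom at this position is enough to move the number well beyond the scatter. No measurement at hand accounts for this loss.

Compound 2 carries the same chloro on its core yet gives 2390 nM in this assay, so the chloro does not go with so high a number in every compound shown. On these data alone, whether a methyl or a methoxy group at this position would bring a similar loss remains open.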